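The compounds below may be only part of what the source reports. "The series", "measured", "known", "first", "only" and "open" are said of these compounds alone.

In a functional assay on Huh-5-2 cells (Homo sapiens) for cytotoxicity, read by microscopy (on this read-out lower numbers stand for higher toxicity in this test and higher numbers for lower toxicity in this test), compound 1 (`CC(=O)OC[C@H]1O[C@@H](n2c(SCc3cc4ccccc4oc3=O)nc3cncnc32)[C@H](O)[C@@H]1O`) gives 8700 nM and compound 2 (`CC(=O)OC[C@H]1O[C@@H](n2c(SCc3cc4cc(F)ccc4oc3=O)nc3cncnc32)[C@H](O)[C@@H]1O`) gives 8600 nM so the two stand level within the usual scatter. Compound 3 (`COc1cccc2cc(CSc3nc4cncnc4n3[C@@H]3O[C@H](COC(C)=O)[C@@H](O)[C@H]3O)c(=O)oc12`) differs from compound 1 by methoxy in place of hydrogen on an aromatic carbon. For the measured compounds named here, the one measured step that bears on this, fluoro in place of hydrogen on an aromatic carbon, is small (a 1.0-fold lower number from compound 1 to compound 2 (0.01 log units; within the scatter)) and lies within the scatter. Methoxy is a different group, so this single step guides only loosely, yet nothing measured points to a step beyond the scatter. The expected change is small (a 1.0-fold lower number from compound 1 to compound 3 (0.01 log units; within the scatter)). Compound 3 is estimated at 8500 nM with a range from 3500 nM to 20000 nM (an expectation, not a measurement).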

Compound 3, half-maximal cytotoxic concentration: 11000 nM
Beside the measured number, compound 3's estimate is 1.3-fold (0.11 log units) below it; low and high end bracket the measured number.
By their numbers in this assay, from the lowest: compounds 2, 1 and 3 (each within the scatter of the next).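

In this assay, methoxy in place of hydrogen on this aromatic carbon gives a 1.3-fold higher number from compound 1 to compound 3 (0.10 log units; within the scatter) and so leaves the read-out level within the scatter. The earlier compounds shown here showed only a fluoro group entering, whereas this step shows that a group of 2 heavy atoms, one of them oxygen, can also enter on an aromatic carbon of the shared core without a change beyond the scatter. No available evidence explains this result. As far as these compounds go, whether an amine, a carboxylic acid or a longer chain such as butoxy on this carbon would also keep the number level remains open.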